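Straight Pentyl in Place of Branched Isopropyl

This account rests on a few compounds, and the source may have more. Where it says the series, first, only, none or still open, it means among the compounds named here.

Measured so far:
compound 1, `CCc1cn([C@H]2C[C@@H]3OP(=O)(O)OC[C@H]3O2)c(=O)[nH]c1=O`, 60 ug/mL
compound 2, `CC(C)c1cn([C@H]2C[C@@H]3OP(=O)(O)OC[C@H]3O2)c(=O)[nH]c1=O`, > 500 ug/mL

In a functional assay on Raji cells (Homo sapiens) (a lower number here means a stronger inhibitor, a higher number a weaker inhibitor), compound 1 gives 60 ug/mL. For compound 2 the value > 500 ug/mL is a limit of the assay and not a number, as the limit of > 500 ug/mL in this assay, at which 1 of the 2 values shown sits, records. Compound 2 thus stands at the weak end of the two values shown, with only a limit known. For the measured compounds named here, the one measured step, an at least 8.3-fold higher number from compound 1 to compound 2 (0.92 log units; beyond the scatter), came from methyl in place of hydrogen on a saturated chain carbon bound to an aromatic carbon and a saturated chain carbon.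

Compound 3, `CCCCCc1cn([C@H]2C[C@@H]3OP(=O)(O)OC[C@H]3O2)c(=O)[nH]c1=O`, differs from compound 2 by pentyl in place of isopropyl on an aromatic carbon. Going by the values given here, the measured step bears on it only in part: it shows that branching weakened the inhibitor, while no step covers a straight chain longer than ethyl. Compound 3 is therefore expected to give 250 ug/mL, between 50 ug/mL and 1000 ug/mL. That estimate is expected to mean an at least 2.0-fold lower number from compound 2 to compound 3 (0.30 log units; that floor lies within the scatter).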

Compound 3, concentration for 50% inhibition: > 500 ug/mL
Compound 3: no number, only a limit; the forecaster's own chance of this, stated with the estimate: 45%; middle value at least 2.0-fold (0.30 log units) away from the limit.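

In this assay compound 3 is recorded only as a limit of the assay, not as a number: the limit of > 500 ug/mL in this assay, at which 2 of the 3 values shown sit.

The straight pentyl chain thus gives an at least 8.3-fold higher number from compound 1 to compound 3 (0.92 log units; beyond the scatter), so in the compounds shown, the loss at this position is not confined to the branched isopropyl group: of the three, only the ethyl group of compound 1 gives a number. The step from compound 2 to compound 3 cannot be read, as both values are limits, so isopropyl and pentyl cannot be ranked against each other.

Still open, as far as these compounds go, is how a methyl group or a straight propyl chain would read in this assay, and so how far the chain can grow beyond ethyl before the number reaches the limit. Also open, from the compounds shown here alone, is whether a hydroxyl group at the end of the pentyl chain would bring a measurable value back.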